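Adding a second trifluoromethyl to the benzamide series

The compounds below may be only part of what the source reports. "The series", "measured", "known", "first", "only" and "open" are said of these compounds alone.

Three compounds share a core and differ in the group attached to the amide-type nitrogen. In a functional assay on MDA-MB-468 cells (Homo sapiens) for inhibition, read by sulforhodamine B assay, with a stated time of 48 h, tested at 10 uM (a lower number here means a stronger effect, a higher number a weaker effect of the compound at the concentration tested), compound 1 `COc1cc(Cl)cc(-c2nn(-c3cccc(NC(=O)Nc4ccc(Cl)c(Cl)c4)c3)cc2-c2ccncc2)c1` gives 0.72%, compound 2 `COc1cc(Cl)cc(-c2nn(-c3cccc(NC(=O)Nc4cccc(C(F)(F)F)c4)c3)cc2-c2ccncc2)c1` gives 6.89%, and compound 3 `COc1cc(Cl)cc(-c2nn(-c3cccc(NC(=O)c4cccc(C(F)(F)F)c4)c3)cc2-c2ccncc2)c1` gives 47%, the highest of the three numbers, so it shows the weakest effect. The large steps of a number 46.3 percentage points higher from compound 1 to compound 3 (beyond the scatter) and a number 40.1 percentage points higher from compound 2 to compound 3 (beyond the scatter) both concern replacing an amino-linked group by a directly attached aryl, while a number 6.2 percentage points higher from compound 1 to compound 2 (within the scatter) shows that swapping one distal aryl group for another changes little. Compound 4 `COc1cc(Cl)cc(-c2nn(-c3cccc(NC(=O)c4cc(C(F)(F)F)cc(C(F)(F)F)c4)c3)cc2-c2ccncc2)c1` differs from compound 3 by trifluoromethyl in place of hydrogen on an aromatic carbon. For the measured compounds named here, no measured step changes a substituent on this aryl, so only a small step, within the scatter, is expected: a number 3 percentage points higher from compound 3 to compound 4 (within the scatter). Compound 4 is thus estimated at 50%, between 30% and 70%.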

Compound 4, a percentage reported as activity, at one concentration (the size of the read-out at that concentration, not a potency): 46.5%
For compound 4 the middle estimate is 3.5 percentage points above the measured one; the measured number falls inside the stated range.
By their numbers in this assay, from the lowest: compounds 1 and 2 (each within the scatter of the next); then compounds 4 and 3 (each within the scatter of the next).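

In this assay, placing a second trifluoromethyl on an aromatic carbon, meta to the first trifluoromethyl group, gives a number 0.5 percentage points lower from compound 3 to compound 4 (within the scatter). For the compounds shown here, this is the first measured change of a substituent on this aryl ring, and at this position the added group leaves the read-out within the scatter. Nothing measured here explains this result.

Going by these compounds, whether an amine or a carboxylic acid at the same position would also leave the read-out within the scatter stays open. So does whether a second trifluoromethyl would behave the same way on the amino-linked aryl of compound 2.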